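Swapping Cyclopentyl for a Fluorinated Chain: Plasma Binding Outlook

A few compounds are considered here, and "the series" means these few. Any claim that something is new, unique, unknown or untested is made for them only; others in the source may bear on it.

Measured so far:
compound 1 `Cc1ccc(C(=O)Nc2cn3ncnc3c(CN3CCN(C(=O)C4CCCC4)[C@@H](C)C3)c2C)cn1`: 77.3%
compound 2 `Cc1ccc(C(=O)Nc2cc(F)cc(CN3CCN(C(=O)C4CCCC4)[C@@H](C)C3)c2C)cn1`: 99.7%

In an ADME assay on a cell-free system (plasma, Homo sapiens) for protein binding, compound 1 gives 77.3%, while compound 2 gives 99.7%. Of these two, compound 1 has the larger unbound fraction, and its distance from compound 2 lies well beyond the usual scatter of repeated measurements. Compound 3 `Cc1ccc(C(=O)Nc2cn3ncnc3c(CN3CCN(C(=O)CC(C(F)(F)F)C(F)(F)F)[C@@H](C)C3)c2C)cn1` has not yet been measured. It differs from compound 1 in a single place: 3,3,3-trifluoro-2-(trifluoromethyl)propyl in place of cyclopentyl on a carbonyl carbon. Going by the values given here, no pair of measured compounds shows this same change, so its effect cannot be read off from the data; only an expectation can be given. The expectation is that compound 3 will be more strongly bound than compound 1, with an estimated step of a 2.8-fold lower unbound fraction from compound 1 to compound 3 (0.45 log units; beyond the scatter) in this assay, beyond the scatter. Compound 3 is therefore estimated at 92% in this assay, with an expected range from 83% to 97%.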

Compound 3, plasma protein binding in the Homo sapiens assay: 86.1%
The estimate for compound 3 lay 1.7-fold (0.24 log units) (unbound fraction) below the measured number; measured number inside the range.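

In the Homo sapiens assay, putting 3,3,3-trifluoro-2-(trifluoromethyl)propyl in place of cyclopentyl on the carbonyl carbon gives a 1.6-fold lower unbound fraction from compound 1 to compound 3 (0.21 log units; within the scatter), so at this position an open chain carrying fluorine can replace a carbon ring without a step beyond the scatter. In a physicochemical assay for solubility, at pH 6.8 (on this read-out lower numbers stand for lower solubility and higher numbers for higher solubility), compound 1 gives 190000 nM and compound 3 gives 200000 nM, two values within the scatter of each other, so neither read-out separates the two groups. No measurement at hand speaks to the cause of these results.

From the compounds shown here alone, it remains open whether a carboxylic acid, an amine or a longer carbon chain at this position would give a step beyond the scatter. Going by these compounds, it is also open whether the same exchange on the core of compound 2 would give a similar step.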